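This account rests on a few compounds, and the source may have more. Where it says the series, first, only, none or still open, it means among the compounds named here.

Working notes on the series. Of the compounds shown here, three of a shared core have been read in an assay on membranes from Chem-1 cells for displacement of a labelled ligand from prostaglandin E2 receptor EP3 subtype (Homo sapiens), read by scintillation counting, with a stated time of 2 h; a lower number here means a stronger inhibitor, a higher number a weaker inhibitor. Compound 1 `C/C(=C1/OC(=O)NC1=O)C(c1ccc(-c2ccc3cccc(F)c3c2)[nH]c1=O)C(C)C` gives 17 nM in this assay. Within the data shown here, compound 3 `CC(C)C(/C=C1/C(=O)NC(=O)N1C)c1ccc(-c2ccc3cccc(F)c3c2)[nH]c1=O` gives 6 nM, and the one measured step that links two of the compounds, a 2.8-fold lower number from compound 1 to compound 3 (0.45 log units; beyond the scatter), runs through a ring swap on the saturated chain carbon. Compound 2 `O=C1NC(=O)/C(=C/C(c2ccc(-c3ccc4cccc(F)c4c3)[nH]c2=O)C2CCCCC2)O1` gives 4 nM, the smallest number of the three in this assay; compound 3 lies within the scatter of it, so the two are not separated, while compound 1 sits beyond the scatter above it. Compound 1 and compound 2 differ in two places at once, so their values say nothing on either change alone.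

Compound 4 `O=C1NC(=O)/C(=C/C(c2ccccc2)c2ccc(-c3ccc4cccc(F)c4c3)[nH]c2=O)O1` is the next entry. It differs from compound 2 by phenyl in place of cyclohexyl on a saturated chain carbon bound to an aromatic carbon and a double-bonded chain carbon. Among the measured compounds shown here, no measured step in this assay touches the group on that saturated chain carbon, so there is nothing to scale an expectation from; the only guide is that compound 2 and compound 3 both sit near the low end in this assay. The step from compound 2 to compound 4 in this assay is therefore expected to be a 1.5-fold higher number from compound 2 to compound 4 (0.18 log units; within the scatter), not beyond the scatter. Compound 4 is estimated at 6 nM in this assay, in a range from 2 nM to 18 nM.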

Compound 4, inhibition constant: 23 nM
Compound 4: middle estimate off by 3.8-fold (0.58 log units), on the low side; measured number outside the range, above it.
By their numbers in this assay, from the lowest: compounds 2 and 3 (each within the scatter of the next); then compounds 1 and 4 (each within the scatter of the next).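

In this assay the group on the saturated chain carbon bound to an aromatic carbon and a double-bonded chain carbon is now shown to matter, with a 5.8-fold higher number from compound 2 to compound 4 (0.76 log units; beyond the scatter) when phenyl stands in place of cyclohexyl. Among these compounds, this is the first measured step at this place, and it lies beyond the scatter even though both groups are six-membered rings of six carbon atoms, with no hydrogen-bond donors or acceptors and no net charge; what changes between them is a non-aromatic ring giving way to an aromatic one, so the count of heavy atoms alone does not set the reading here. No supporting measurement accompanies this step, and the difference therefore stands as an observation without an explanation.

As far as these compounds go, this place rests on a single pair, so it remains open whether a cyclopentyl group or a pyridyl ring there would read with cyclohexyl or with phenyl. Among the compounds shown here, it is equally open whether the phenyl-for-cyclohexyl step would keep its size on the other five-membered ring carried by compound 3, as no pair on that ring tests this change.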